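The compounds below may be only part of what the source reports. "The series", "measured", "known", "first", "only" and "open" are said of these compounds alone.

In an assay on isolated protein for inhibition of Nitric oxide synthase, inducible (Homo sapiens), with a stated time of 30 min, tested at 1 mM (on this read-out lower numbers stand for less inhibition and higher numbers for more inhibition at the one concentration tested (going by the name of the read-out)), three compounds have been measured so far. Compound 1 `COc1ccc(N)c(C2=NN(C(=O)C3CC3)CC2)c1` gives 19.9%. Compound 2 `COc1ccc(N)c(C2=NN(C(=O)c3ccccc3)CC2)c1` differs from compound 1 by phenyl in place of cyclopropyl on a carbonyl carbon, and in this assay compound 2 gives 12.2%; the step is a number 7.7 percentage points lower from compound 1 to compound 2 (within the scatter), so the two values cannot be told apart. Compound 3 `Nc1cc(Cl)c(Cl)cc1C1=NN(C(=O)C2CC2)CC1` rests on a different core, and the difference between the two cores is not broken down here; in this assay compound 3 gives 15.5%, a number within the scatter of both compound 1 and compound 2.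

Compound 4 `Nc1cc(Cl)c(Cl)cc1C1=NN(C(=O)c2ccccc2)CC1` has not yet been measured. It differs from compound 3 by phenyl in place of cyclopropyl on a carbonyl carbon, the same change made from compound 1 to compound 2, and at the same place. Because that earlier change gave a number 7.7 percentage points lower from compound 1 to compound 2 (within the scatter), the expected step is small: compound 4 is estimated to move by a number 5.5 percentage points lower from compound 3 to compound 4 (within the scatter) from compound 3. Compound 4 is therefore expected to show roughly 10% in this assay, most likely between 0% and 22%.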

Compound 4, a percentage reported as inhibition, at one concentration (the size of the read-out at that concentration, not a potency): 36.1%
Compound 4: middle estimate off by 26.1 percentage points, on the low side, and the stated range ends below it.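

In this assay, phenyl in place of cyclopropyl on a carbonyl carbon gives a number 20.6 percentage points higher from compound 3 to compound 4 (beyond the scatter), a step large enough to count as real. The same swap does not carry over unchanged from one core to the other, so the result of a change on one core is a poor guide to its result on the other: the same change on two cores in this assay, a number 7.7 percentage points lower (within the scatter) from compound 1 to compound 2 and a number 20.6 percentage points higher (beyond the scatter) from compound 3 to compound 4, 28.3 percentage points apart, beyond the scatter of two such steps This does not explain why the two cores respond differently, and two cores are too few to predict the direction of the step on a third.

The compounds shown leave open how other groups on the same carbonyl carbon, such as an amine, a carboxylic acid or a longer chain, would behave on either core. They also leave potency open, as each reading gives the size of the inhibition at a single concentration.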